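This account rests on a few compounds, and the source may have more. Where it says the series, first, only, none or still open, it means among the compounds named here.

In a physicochemical assay for lipophilicity (a lower number here means a more polar compound, a higher number a more lipophilic compound), compound 3 `CCNC(=O)Nc1ccc(-c2nccc([C@@]34CCOC[C@@H]3C4)n2)cc1` gives 3.9, level with compound 1 `CCNC(=O)Nc1ccc(-c2nccc([C@]34CCOC[C@H]3C4)n2)cc1` at 3.9. Together they hold the highest of the three numbers so far. Compound 2 `Oc1cccc(-c2nccc(C3CCOCC3)n2)c1` stands lower at 3.3, beyond the scatter from both.

Next in the series is compound 4 `CCNC(=O)Nc1ccc(-c2nccc(C34CCOCC3C4)n2)cc1`, and the change is the two compounds have the same atoms and bonds; at least one stereo element is drawn with a configuration in one of them and without one in the other: 2 of 2 stereo elements differ; a stereocentre at a saturated ring carbon is drawn S in compound 3 and without a configuration in compound 4; a stereocentre at a saturated ring carbon is drawn R in compound 3 and without a configuration in compound 4. It has the same atoms and bonds as compound 3, and both stereocentres at saturated ring carbons are drawn without a configuration.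

Among the measured compounds shown here, the only measured step that bears on this is no change at the digits printed from compound 1 to compound 3 (within the scatter), resting on (the fact that compounds 1 and 3 differ only in the configuration as drawn). On the strength of that step, no change beyond the scatter is expected in this assay, in either direction. The estimated size of the step is no change at the digits printed from compound 3 to compound 4 (within the scatter). For compound 4 the expected value is 3.9, with an estimated range of 3.6 to 4.2.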

Compound 4, partition coefficient: 4
For compound 4 the middle estimate is 0.10 log units below the measured one; the measured number falls inside the stated range.
By their numbers in this assay, from the lowest: compound 2; then compounds 1, 3 and 4 (each within the scatter of the next).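

In this assay there is a number 0.10 log units higher from compound 3 to compound 4 (within the scatter) and a number 0.10 log units higher from compound 1 to compound 4 (within the scatter) as well, so the drawing without a configuration does not separate from either drawn mirror image. Until now only compound 1 and compound 3 bore on configuration at these two saturated ring carbons; compound 4 adds a third drawing, with neither stereocentre defined. Across these three compounds, configuration as drawn shows no difference beyond the scatter, and none of the three goes against that.

The drawing of compound 4 does not tell whether the sample is a single form or a mixture. Also open, as far as these compounds go, is how this assay would respond to an amine or a carboxylic acid on the saturated ring system, and whether configuration would still make no difference there.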